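This account rests on a few compounds, and the source may have more. Where it says the series, first, only, none or still open, it means among the compounds named here.

Values in an ADME assay on the whole organism (plasma, Rattus norvegicus, strain Sprague-Dawley) for pharmacokinetics, read by LC-MS, with a stated time of 4 h, at a dose of 15 mg/kg by the intraduodenal route; on this read-out lower numbers stand for lower exposure and higher numbers for higher exposure at the dose given:
- compound 1 `C=C[C@@H]1C[C@]1(NC(=O)[C@@H]1C[C@@H](Oc2cc(-c3ccccc3)nc3cc(OC)ccc23)CN1C(=O)[C@@H](NC(=O)OC(C)(C)C)C(C)(C)C)C(=O)NS(=O)(=O)C1CC1`: 61 ng.h/mL
- compound 2 `C=C[C@@H]1C[C@]1(NC(=O)[C@@H]1C[C@@H](Oc2cc(-c3ccccc3)nc3cc(OC)ccc23)CN1C(=O)[C@@H](NC(=O)N(C)C(C)(C)C)C(C)(C)C)C(=O)NS(=O)(=O)C1CC1`: 32 ng.h/mL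
- compound 3 `C=C[C@@H]1C[C@]1(NC(=O)[C@@H]1C[C@@H](Oc2cc(-c3ccccc3)nc3cc(OC)ccc23)CN1C(=O)[C@@H](OC(=O)NC(C)(C)C)C(C)(C)C)C(=O)NS(=O)(=O)C1CC1`: 82 ng.h/mL

Compound 3, at 82 ng.h/mL, cannot be separated from compound 1: a 1.3-fold higher number from compound 1 to compound 3 (0.13 log units; within the scatter). Its only clear gap is to compound 2, a 2.6-fold higher number from compound 2 to compound 3 (0.41 log units; beyond the scatter). The next compound is compound 4 `C=C[C@@H]1C[C@]1(NC(=O)[C@@H]1C[C@@H](Oc2cc(-c3ccccc3)nc3cc(OC)ccc23)CN1C(=O)[C@@H](OC(=O)NC1CCCC1)C(C)(C)C)C(=O)NS(=O)(=O)C1CC1`, with this difference: cyclopentyl in place of tert-butyl on an amide-type nitrogen. In short, cyclopentyl stands in place of tert-butyl on an amide-type nitrogen.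

Among the compounds with values here, no measured step makes this exchange, so the evidence is indirect. All three measured compounds keep the tert-butyl and vary other atoms, and the remaining step is a 1.9-fold lower number from compound 1 to compound 2 (0.28 log units; within the scatter). The largest of these changes is only modest, so a step beyond the scatter is not expected in this assay, and no direction is favoured. The estimated step is a 1.2-fold lower number from compound 3 to compound 4 (0.07 log units; within the scatter). Compound 4 is estimated at 70 ng.h/mL, with an expected range of 30 ng.h/mL to 160 ng.h/mL.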

Compound 4, area under the concentration-time curve: 95 ng.h/mL
Estimate against measurement, compound 4: 1.4-fold (0.13 log units) below, within the range that was stated.
By their numbers in this assay, from the lowest: compounds 2, 1, 3 and 4 (each within the scatter of the next, the first and the last beyond it).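

In this assay the only exchange shown on the amide-type nitrogen, cyclopentyl in place of tert-butyl, gives a 1.2-fold higher number from compound 3 to compound 4 (0.06 log units; within the scatter) and so leaves no separable change in exposure, which means that a five-membered non-aromatic ring of carbon only is tolerated at this position. Compound 4 also repeats the picture of compound 3, with a 1.6-fold higher number from compound 1 to compound 4 (0.19 log units; within the scatter) and no clear gap there, while a 3.0-fold higher number from compound 2 to compound 4 (0.47 log units; beyond the scatter) is its one clear gap. No measurement at hand bears on the cause of these numbers.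

Open, from the compounds shown here alone, is whether cyclopropyl, cyclohexyl or a phenyl ring on the same nitrogen would hold exposure, and whether a basic amine or a carboxylic acid carried on that ring would do so. Also open, going by these compounds, is whether cyclopentyl gives the same result with the methyl(tert-butyl)amino series.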